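The compounds below may be only part of what the source reports. "The series", "measured", "known", "first", "only" and "open" are said of these compounds alone.

The measured compounds:

Compound 1, `O=C1C(=Cc2ccc(O)cc2)C(=O)N(c2ccc(Cl)cc2)N1c1ccc(Cl)cc1`, gives 20600 nM in a functional assay on SMMC-7721 cells (Homo sapiens) for cytotoxicity, read by MTT assay, with a stated time of 72 h; on this read-out lower numbers stand for stronger inhibition and higher numbers for weaker inhibition.
Compound 2, `O=C1C(=Cc2ccc(F)cc2)C(=O)N(c2ccc(Cl)cc2)N1c1ccc(Cl)cc1`, gives 23300 nM in this assay.
Compound 3, `COc1cc(C=C2C(=O)N(c3ccc(Cl)cc3)N(c3ccc(Cl)cc3)C2=O)ccc1O`, gives 64900 nM in this assay.

Compound 2 stands second highest of these three numbers. Its nearest neighbour is compound 1, with a 1.1-fold higher number from compound 1 to compound 2 (0.05 log units; within the scatter), a difference too small to read as real; its furthest is compound 3, with a 2.8-fold higher number from compound 2 to compound 3 (0.44 log units; beyond the scatter), a modest weakening.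

Compound 4 is `O=C1C(=C/C=C/c2ccccc2)C(=O)N(c2ccc(Cl)cc2)N1c1ccc(Cl)cc1`. The change from compound 2 is 2-phenylethenyl in place of 4-fluorophenyl on a double-bonded chain carbon bound to a double-bonded ring carbon. All three measured steps concern the same position, so all bear on it: the swap of fluoro for hydroxy gave a 1.1-fold higher number from compound 1 to compound 2 (0.05 log units; within the scatter), adding methoxy gave a 3.2-fold higher number from compound 1 to compound 3 (0.50 log units; beyond the scatter), and the larger swap gave a 2.8-fold higher number from compound 2 to compound 3 (0.44 log units; beyond the scatter). None of these steps tested a 2-phenylethenyl group, so the direction is uncertain, but every change so far at this position moved the number by a modest amount at most. The expected step in this assay is therefore small, within or just beyond the scatter, in either direction, meaning a 1.2-fold lower number from compound 2 to compound 4 (0.07 log units; within the scatter). Compound 4 is thus estimated at 20000 nM, with a range from 7000 nM to 60000 nM.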

Compound 4, half-maximal inhibitory concentration: 10100 nM
The estimate for compound 4 lay 2.0-fold (0.30 log units) above the measured number, and the stated range covers the measured number.
By their numbers in this assay, from the lowest: compound 4; then compounds 1 and 2 (each within the scatter of the next); then compound 3.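

In this assay, compound 4 has the lowest number of the four compounds, and each of its steps lies beyond the scatter: a 2.0-fold lower number from compound 1 to compound 4 (0.31 log units; beyond the scatter) and a 2.3-fold lower number from compound 2 to compound 4 (0.36 log units; beyond the scatter) and a 6.4-fold lower number from compound 3 to compound 4 (0.81 log units; beyond the scatter). So the group on the double-bonded chain carbon bound to a double-bonded ring carbon can do more than the ring substituents alone suggested, since 2-phenylethenyl gives a lower number than the 4-hydroxyphenyl, 4-fluorophenyl and 4-hydroxy-3-methoxyphenyl groups, though all of these steps remain modest. Nothing measured here explains this shift.

The compounds shown cannot separate the effect of the 1 double bond outside aromatic rings from that of losing the ring substituents, and a 2-phenylethyl chain or a longer chain with a further double bond would help to tell these apart. From the compounds shown here alone, it also remains open whether fluoro, hydroxy, methoxy or an amine on the phenyl ring of the 2-phenylethenyl group would move the number further in either direction.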